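Replacing a fluorophenyl with a methoxyphenyl on the sulfonyl

The source may hold more compounds than are shown below. What is called first, only, known or untested is meant among the compounds shown, and "the series" means these compounds.

Of the compounds shown here, three sharing one core have been measured in an assay on isolated protein for displacement of a labelled ligand from metabotropic glutamate receptor 5 (Homo sapiens), with a stated time of 60 min, tested at 1 uM; a lower number here means less inhibition, a higher number more inhibition at the concentration tested (going by the name of the read-out). Compound 1 `CC1CCN(c2c(S(=O)(=O)c3ccc(C#N)cc3)cnc3c(F)cccc23)CC1` gives 86%, and compound 2 `Cc1ccc(S(=O)(=O)c2cnc3c(F)cccc3c2N2CCC(C)CC2)cc1F` gives 93%, a difference of a number 7 percentage points higher from compound 1 to compound 2 (within the scatter). Compound 3 `CC1CCN(c2c(S(=O)(=O)c3cccc(F)c3)cnc3c(F)cccc23)CC1` gives 62%, the lowest of the three numbers: the step of a number 24 percentage points lower from compound 1 to compound 3 (beyond the scatter) and the step of a number 31 percentage points lower from compound 2 to compound 3 (beyond the scatter) both lie beyond the scatter, so compound 3 stands clearly apart from compound 1 and compound 2.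

Compound 4 `COc1ccc(S(=O)(=O)c2cnc3c(F)cccc3c2N2CCC(C)CC2)cc1` differs from compound 3 in one place: 4-methoxyphenyl in place of 3-fluorophenyl on a sulfonyl sulfur. Going by the values given here, two measured steps bear on this change. Both the step of a number 24 percentage points lower from compound 1 to compound 3 (beyond the scatter) and the step of a number 31 percentage points lower from compound 2 to compound 3 (beyond the scatter) end at the 3-fluorophenyl group of compound 3 and run downward, so swapping that group for another phenyl bearing a different substituent is expected to run upward, by a moderate step. The expected change is a number 18 percentage points higher from compound 3 to compound 4 (beyond the scatter). Compound 4 is therefore estimated to reach 80%, within a range from 60% to 95%.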

Compound 4, a percentage reported as inhibition, at one concentration (the size of the read-out at that concentration, not a potency): 67%
Estimate against measurement, compound 4: 13 percentage points above; measured number inside the range.
By their numbers in this assay, from the lowest: compounds 3 and 4 (each within the scatter of the next); then compounds 1 and 2 (each within the scatter of the next).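

In this assay, changing the substituent on the phenyl group does not by itself raise the number: 4-methoxyphenyl in place of 3-fluorophenyl stays within the scatter (a number 5 percentage points higher from compound 3 to compound 4 (within the scatter)). The low level is therefore no longer tied to compound 3 alone, since 4-methoxyphenyl also falls short of both higher compounds (a number 26 percentage points lower from compound 2 to compound 4 (beyond the scatter); a number 19 percentage points lower from compound 1 to compound 4 (beyond the scatter)). The four compounds now form two groups, with 4-cyanophenyl and 3-fluoro-4-methylphenyl above 3-fluorophenyl and 4-methoxyphenyl, but nothing available explains this split.

On these data alone, it remains open whether the substituent itself or its place on the ring sets the level, which 3-methoxyphenyl and 4-fluorophenyl groups could help separate. How an unsubstituted phenyl group or a pyridine ring on the sulfonyl sulfur would read is also unknown.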